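The source may report more compounds than this note shows. Statements on the series, on what has been measured and on what is new or still open speak of the compounds shown alone.

Measured compounds:

Compound 1, `Cc1cc(-n2cc(C(=O)Nc3cc(F)cc(F)c3)c(=O)c3ccc(N(C)C)nc32)ccc1OCCCCCCC[N+]1(C)CCN(C)CC1`: 32%
Compound 2, `Cc1cc(OCCCCCCC[N+]2(C)CCN(C)CC2)cc(-n2cc(C(=O)Nc3cc(F)cc(F)c3)c(=O)c3ccc(N(C)C)nc32)c1`: 38.2%
Compound 3, `CC[N+]1(CCCCCCCOc2ccc(-n3cc(C(=O)Nc4cc(F)cc(F)c4)c(=O)c4ccc(N(C)C)nc43)cc2C)CCCC1`: 82.5%

All three were tested in an assay on LX2 cells for inhibition of COL1A1 promoter (Homo sapiens), read by a luciferase reporter, with a stated time of 24 h, tested at 50 uM; a higher number here means a stronger effect of the compound at the concentration tested, a lower number a weaker effect. Compound 1 and compound 2 share the same atoms joined differently; the difference between the two cores is not broken down here, and their two values lie within the scatter of each other. From compound 1 to compound 3 the change is a group of 7 heavy atoms (6 carbon, 1 nitrogen; one five-membered non-aromatic ring with 1 hetero atom) in place of a group of 8 heavy atoms (6 carbon, 2 nitrogen; one six-membered non-aromatic ring with 2 hetero atoms), on a saturated chain carbon, seven bonds along the chain from an oxygen on an aromatic ring, and it gave a number 50.5 percentage points higher from compound 1 to compound 3 (beyond the scatter).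

Compound 4, `CC[N+]1(CCCCCCCOc2cc(C)cc(-n3cc(C(=O)Nc4cc(F)cc(F)c4)c(=O)c4ccc(N(C)C)nc43)c2)CCCC1`, has not yet been measured. It differs from compound 2 by a group of 7 heavy atoms (6 carbon, 1 nitrogen; one five-membered non-aromatic ring with 1 hetero atom) in place of a group of 8 heavy atoms (6 carbon, 2 nitrogen; one six-membered non-aromatic ring with 2 hetero atoms), on a saturated chain carbon, seven bonds along the chain from an oxygen on an aromatic ring, the same change as from compound 1 to compound 3. Because compound 1 to compound 3 gave a number 50.5 percentage points higher from compound 1 to compound 3 (beyond the scatter), a step of a number 46.8 percentage points higher from compound 2 to compound 4 (beyond the scatter) is expected from compound 2 to compound 4. Compound 4 is therefore estimated at 85%, within 60% to 100%.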

Compound 4, a percentage reported as inhibition, at one concentration (the size of the read-out at that concentration, not a potency): 73.2%
For compound 4 the middle estimate is 11.8 percentage points above the measured one; low and high end bracket the measured number.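

The swap of the six-membered ring with two hetero atoms for the five-membered ring with one hetero atom again gives a number 35 percentage points higher from compound 2 to compound 4 (beyond the scatter) in this assay. Among these compounds, the direction of the change therefore carries over between these two cores, but its size does not: the same change on two cores in this assay, a number 50.5 percentage points higher (beyond the scatter) from compound 1 to compound 3 and a number 35 percentage points higher (beyond the scatter) from compound 2 to compound 4, 15.5 percentage points apart, beyond the scatter of two such steps With only two cores, this does not show that the gain would appear on any other core, nor why its size differs.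

The swap alters ring size and nitrogen count together, so the compounds shown cannot separate the two. A piperidine or morpholine ring at the chain end would help to do so, and a shorter or longer chain remains an open question.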